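The source may hold more compounds than are shown below. What is called first, only, known or untested is meant among the compounds shown, and "the series" means these compounds.

Compound 1, `CC1(C)[C@H](c2cc(Cl)cc(Cl)c2)[C@H]1c1c[nH]c(N)n1`, in a functional assay on AP1 cells for inhibition of sodium/hydrogen exchanger 1 (Homo sapiens); a lower number here means a stronger inhibitor, a higher number a weaker inhibitor: 180 nM
Compound 2, `Cc1[nH]cnc1[C@@H]1[C@@H](c2cc(Cl)cc(Cl)c2)C1(C)C`, in this assay: 950 nM
Compound 3, `CC1(C)[C@H](c2cccc(Cl)c2)[C@H]1c1c[nH]c(N)n1`, in this assay: 750 nM

Compound 3 holds the second highest of the three numbers; its value sits within the scatter of compound 2 and is set apart from compound 1 by a 4.2-fold higher number from compound 1 to compound 3 (0.62 log units; beyond the scatter), a change that came from swapping one chloro for hydrogen on an aromatic carbon. The new compound, compound 4, `CC1(C)[C@H](c2cccc(Cl)c2)[C@H]1c1cnc(N)s1`, keeps that single chloro and instead alters the ring group on the saturated ring carbon: 2-amino-1,3-thiazol-5-yl in place of 2-amino-1H-imidazol-4-yl on a saturated ring carbon. Among the measured compounds shown here, the only measured step that touches this position is a 5.3-fold higher number from compound 1 to compound 2 (0.72 log units; beyond the scatter), where the 2-amino group was lost and a weaker inhibitor resulted. Compound 4 keeps an amino group but changes the ring that carries it, so a shift of that kind, though probably smaller, is expected. The estimate for compound 4 is therefore 2000 nM, within 600 nM to 7000 nM, meaning an expected step of a 2.7-fold higher number from compound 3 to compound 4 (0.43 log units; beyond the scatter).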

Compound 4, half-maximal inhibitory concentration: 8000 nM
For compound 4 the middle estimate is 4.0-fold (0.60 log units) below the measured one; the measured number lies above the stated range.
By their numbers in this assay, from the lowest: compound 1; then compounds 3 and 2 (each within the scatter of the next); then compound 4.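

Swapping the ring alone, with the amino group kept, gives an 11-fold higher number from compound 3 to compound 4 (1.03 log units; beyond the scatter), so the group on the saturated ring carbon is sensitive to more than the presence of that amino group. The earlier step at this carbon, a 5.3-fold higher number from compound 1 to compound 2 (0.72 log units; beyond the scatter), removed the amino group and added a methyl group, so it could not show this; here, the 2-amino-1,3-thiazol-5-yl ring has a sulfur in place of one nitrogen, with one hydrogen-bond donor fewer and one acceptor more than 2-amino-1H-imidazol-4-yl. Nothing available explains why this swap weakens inhibition so much.

On these data alone, it remains open whether the same swap would have a similar effect with both chloro groups present, as in compound 1. Also open, as far as these compounds go, is how a 2-amino-1,3-oxazol-5-yl ring, with oxygen in place of the sulfur, would behave at this carbon.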